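A few compounds are considered here, and "the series" means these few. Any claim that something is new, unique, unknown or untested is made for them only; others in the source may bear on it.

Measured so far:
- compound 1, `COC(=O)c1sccc1NC(=O)CSc1nncnc1-c1ccccc1Cl`: 105000 nM
- compound 2, `CCOC(=O)c1ccc(NC(=O)CSc2nncnc2-c2ccccc2Cl)c(Br)c1`: 69000 nM

Both numbers come from an ADME assay on MT4 cells (Homo sapiens) for cytotoxicity, read by MTT assay; a higher number here means that more compound is tolerated, a lower number that less compound is tolerated. Compound 1 gives the highest of the two numbers in this assay; the nearest is compound 2, and the gap between the two lies within the scatter, so no order can be read from this pair.

Compound 3, `Cc1ccccc1NC(=O)CSc1nncnc1-c1ccccc1Cl`, has not yet been measured in this assay. It differs from compound 1 at one place: 2-methylphenyl in place of 2-(methoxycarbonyl)thiophen-3-yl on an amide-type nitrogen. The 2-methylphenyl carries no hydrogen-bond acceptors where the 2-(methoxycarbonyl)thiophen-3-yl carried three, and it has fewer heavy atoms.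

Among the measured compounds shown here, no step between measured compounds bears on this change. For the measured compounds named here, the two values so far sit close to each other and give no sign that the group on the amide-type nitrogen moves the number in this assay. The step expected from compound 1 to compound 3 is therefore none beyond the scatter, or at most a small one downward, as a 1.3-fold lower number from compound 1 to compound 3 (0.12 log units; within the scatter) states. For compound 3 in this assay the estimate is 80000 nM, with a range from 30000 nM to 200000 nM.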

Compound 3, half-maximal cytotoxic concentration: 142000 nM
Beside the measured number, compound 3's estimate is 1.8-fold (0.25 log units) below it; measured number inside the range.
By their numbers in this assay, from the lowest: compounds 2, 1 and 3 (each within the scatter of the next, the first and the last beyond it).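

In this assay, among the compounds shown here, the one step at this position, a 1.4-fold higher number from compound 1 to compound 3 (0.13 log units; within the scatter), comes with 2-methylphenyl in place of 2-(methoxycarbonyl)thiophen-3-yl on an amide-type nitrogen, so the two compounds cannot be told apart. For the compounds shown here, this is the first direct reading of a change at this place: a six-membered aromatic ring of carbon only, with no hydrogen-bond acceptors and fewer heavy atoms, stands in for a five-membered aromatic ring with a sulfur atom and the methoxycarbonyl group, and no effect beyond the scatter appears. No measurement available for this series explains the result or says what the number depends on.

A single pair at this position cannot show whether the group on the amide-type nitrogen matters at all in this assay, and a carboxylic acid or a primary amine on the aromatic ring, or a saturated ring such as cyclohexyl in its place, might yet move the number beyond the scatter. On these data alone, the shared core is the same in compound 1 and compound 3, so what it contributes also stays open.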